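From Thiophene to Carboxycyclohexyl on the Shared Core

The source may hold more compounds than are shown below. What is called first, only, known or untested is meant among the compounds shown, and "the series" means these compounds.

In a functional assay on PC-3 cells (Homo sapiens) for cytotoxicity, read by MTT assay (a lower number here means a stronger inhibitor, a higher number a weaker inhibitor), compound 1 `Oc1ccc(CN(Cc2ccccc2)Cc2ccc(O)c3ncccc23)c2cccnc12` gives 258 nM, while compound 2 `Oc1ccc(CN(Cc2cccs2)Cc2ccc(O)c3ncccc23)c2cccnc12` gives 44 nM, the lower of the two numbers. Compound 3 `O=C(O)C1CCC(CN(Cc2ccc(O)c3ncccc23)Cc2ccc(O)c3ncccc23)CC1`, not yet measured, has 4-carboxycyclohexyl in place of thiophen-2-yl on a saturated chain carbon bound to an amine nitrogen. Within the data shown here, the only measured step at this place is a 5.9-fold lower number from compound 1 to compound 2 (0.77 log units; beyond the scatter), which swapped one aromatic ring for another. Here a non-aromatic ring enters, so a step of similar or larger size toward a higher number seems likely. The expected change is an 11-fold higher number from compound 2 to compound 3 (1.06 log units; beyond the scatter). For compound 3 the estimated value is 500 nM, with a range of 100 nM to 2500 nM.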

Compound 3, half-maximal inhibitory concentration: 9940 nM
Compound 3: middle estimate off by 20-fold (1.30 log units), on the low side; the measured number lies above the stated range.
By their numbers in this assay, from the lowest: compound 2; then compound 1; then compound 3.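

In this assay, this position proves far more sensitive than the swap between two aromatic rings suggested: 4-carboxycyclohexyl brings a 230-fold higher number from compound 2 to compound 3 (2.35 log units; beyond the scatter) and also a 39-fold higher number from compound 1 to compound 3 (1.59 log units; beyond the scatter). Both steps are larger than the one between the phenyl and thiophen-2-yl compounds. Nothing measured here gives a cause for the rise.

The change replaces the aromatic ring with a non-aromatic one and adds a carboxyl group, so the two effects cannot be told apart. A plain cyclohexyl or a methyl ester at this place would help separate them.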